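A few compounds are considered here, and "the series" means these few. Any claim that something is new, unique, unknown or untested is made for them only; others in the source may bear on it.

Compound 1 `O=S(=O)(Nc1ccc(-c2nc3ccccc3o2)cc1)c1ccccc1Cl`, compound 2 `CS(=O)(=O)Nc1ccc(-c2nc3ccccc3o2)cc1` and compound 3 `O=S(=O)(Nc1ccc(-c2nc3ccccc3o2)cc1)c1cccs1` share one core and differ only in the group on the sulfonyl sulfur. In an assay on isolated protein for inhibition of malate dehydrogenase, mitochondrial (Sus scrofa), with stated times of 45 min and 30 min (on this read-out higher numbers stand for weaker inhibition and lower numbers for stronger inhibition), compound 1 gives a limit of > 63000 nM. In this assay compound 2 likewise gives a limit of > 63000 nM. Compound 3 stands in this assay at a limit of > 63000 nM. The steps a step that the two limits leave unreadable from compound 1 to compound 2, a step that the two limits leave unreadable from compound 1 to compound 3 and a step that the two limits leave unreadable from compound 2 to compound 3 cannot be sized, given (the limit of > 63000 nM in this assay, at which 3 of the 3 values shown sit). Compound 4 `O=S(=O)(Nc1ccc(-c2nc3ccccc3o2)cc1)c1ccc(O)cc1` carries 4-hydroxyphenyl in place of thiophen-2-yl on a sulfonyl sulfur. For the measured compounds named here, none of the measured steps gives a readable size for this change, so no direction is indicated. Compound 4 is therefore expected to sit at the same limit, with an estimated step that the limit leaves unreadable from compound 3 to compound 4. For compound 4 the expected value in this assay is 90000 nM, with a range from 30000 nM to 300000 nM.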

Compound 4, half-maximal inhibitory concentration: > 63000 nM
Compound 4 gave a limit, no number; the forecaster's own chance of this, stated with the estimate: 80%; the middle value does not contradict the limit.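

Compound 4 adds no readable step against compound 1, compound 2 or compound 3 in this assay, because the values are limits, not numbers: the limit of > 63000 nM in this assay, at which 4 of the 4 values shown sit.

The compounds shown leave open which group on the sulfonyl sulfur, if any, gives a number rather than a limit in this assay.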